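Replacing dimethylamino with hydroxy on the aromatic ring

The compounds below may be only part of what the source reports. "The series", "measured", "known", "first", "only" and "open" are said of these compounds alone.

Going by the values given here, in a functional assay on SW-620 cells (Homo sapiens) for cytotoxicity, read by sulforhodamine B assay, with a stated time of 48 h (a higher number here means a weaker inhibitor, a lower number a stronger inhibitor), compound 3 `C[C@H]1CC[C@@H]2[C@@H](OC(=O)[C@]23CC(c2ccc(N(C)C)cc2)=NO3)[C@]2(C)C(=O)C=C[C@@]12O` gives 5100 nM, the lowest of the three numbers so far. Compound 1 `COc1ccc(C2=NO[C@]3(C2)C(=O)O[C@@H]2[C@H]3CC[C@H](C)[C@]3(O)C=CC(=O)[C@@]23C)cc1` gives 41000 nM and compound 2 `C[C@H]1CC[C@@H]2[C@@H](OC(=O)[C@]23CC(c2ccc(Cl)cc2)=NO3)[C@]2(C)C(=O)C=C[C@@]12O` gives 51000 nM. These two sit close together, with a 1.2-fold higher number from compound 1 to compound 2 (0.09 log units; within the scatter). Compound 4 `C[C@H]1CC[C@@H]2[C@@H](OC(=O)[C@]23CC(c2ccc(O)cc2)=NO3)[C@]2(C)C(=O)C=C[C@@]12O` carries hydroxy in place of dimethylamino on an aromatic carbon. Among the compounds with values here, no measured compound has hydroxy, so only indirect evidence exists. Two measured steps end at dimethylamino: an 8.0-fold lower number from compound 1 to compound 3 (0.91 log units; beyond the scatter) and a 10-fold lower number from compound 2 to compound 3 (1.00 log units; beyond the scatter). Read in reverse, they suggest that leaving dimethylamino should raise the number in this assay by a similar or somewhat smaller amount. The expected change is a 5.9-fold higher number from compound 3 to compound 4 (0.77 log units; beyond the scatter). Compound 4 is estimated at 30000 nM, with a range from 10000 nM to 70000 nM.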

Compound 4, half-maximal inhibitory concentration: 89000 nM
Compound 4: the middle estimate sits 3.0-fold (0.47 log units) below what was measured; measured number above the stated range.
By their numbers in this assay, from the lowest: compound 3; then compounds 1, 2 and 4 (each within the scatter of the next, the first and the last beyond it).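

In this assay, hydroxy does not keep the lower number seen with dimethylamino at this position (a 17-fold higher number from compound 3 to compound 4 (1.24 log units; beyond the scatter)). Hydroxy instead falls in with chloro (a 1.7-fold higher number from compound 2 to compound 4 (0.24 log units; within the scatter)), and removing the methyl from the oxygen of compound 1 gives a small step that lies beyond the scatter (a 2.2-fold higher number from compound 1 to compound 4 (0.34 log units; beyond the scatter)). Nothing available explains these differences. Among the compounds shown, dimethylamino alone gives the lower number. On these data alone, whether another amine on the same aromatic carbon, such as a plain amino group or diethylamino, would do the same remains open.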